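Fluoro for ethynyl: expectation for compound 3

The source may hold more compounds than are shown below. What is called first, only, known or untested is meant among the compounds shown, and "the series" means these compounds.

In an ADME assay on microsomes from liver (Rattus norvegicus) for metabolic stability, read by LC-MS, using NADPH, with a stated time of 10 min, tested at 0.1 uM (a higher number here means faster removal of the compound, a lower number slower removal), compound 2 `C#Cc1cccc(N2C(=O)CSC2c2cccc(C(=O)NCCCCc3ccccc3)c2)c1` gives 1820 mL.min-1.g-1 and compound 1 `O=C(NCCCCc1ccccc1)c1cccc(C2SCC(=O)N2c2ccccn2)c1` gives 1480 mL.min-1.g-1, so the two stand within the scatter of each other. Compound 3 `O=C(NCCCCc1ccccc1)c1cccc(C2SCC(=O)N2c2cccc(F)c2)c1` differs from compound 2 in one place: fluoro in place of ethynyl on an aromatic carbon. This is fluoro in place of ethynyl on an aromatic carbon. Going by the values given here, the only measured step bearing on it, a 1.2-fold higher number from compound 1 to compound 2 (0.09 log units; within the scatter), exchanges the whole group on the ring nitrogen and stays within the scatter. Among the compounds with values here, no measured step removes ethynyl itself, so no change beyond the scatter is expected. The estimated step is a 1.2-fold lower number from compound 2 to compound 3 (0.08 log units; within the scatter). Compound 3 is estimated at 1500 mL.min-1.g-1, with an expected range of 800 mL.min-1.g-1 to 2800 mL.min-1.g-1.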

Compound 3, intrinsic clearance in microsomes: 3240 mL.min-1.g-1
Compound 3: the middle estimate sits 2.2-fold (0.33 log units) below what was measured, and the stated range ends below it.
By their numbers in this assay, from the lowest: compounds 1, 2 and 3 (each within the scatter of the next, the first and the last beyond it).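

In this assay, going by these compounds alone, fluoro in place of ethynyl gives a 1.8-fold higher number from compound 2 to compound 3 (0.25 log units; within the scatter), so this exchange on the aromatic carbon does not separate the two compounds. 3-Fluorophenyl in place of pyridin-2-yl gives a 2.2-fold higher number from compound 1 to compound 3 (0.34 log units; beyond the scatter), the first step at this ring nitrogen to pass the scatter, though only modestly. Nothing available bears on the cause of either step.

Open, as far as these compounds go, is whether a nitrile, a methoxy group or an amine on the same aromatic carbon would stand apart from compound 2 and compound 3 in this assay.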